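Changing the aromatic ring: an estimate for compound 4

The compounds below may be only part of what the source reports. "The series", "measured", "known", "first", "only" and "open" are said of these compounds alone.

Compound 3 `CN(C)CCn1cnnc1-c1cc(Oc2ccc(NC(=O)N/N=C/c3ccc(Cl)cc3)cc2F)ccn1`: in a functional assay on A549 cells (Homo sapiens) for cytotoxicity, read by MTT assay, with a stated time of 72 h (a higher number here means a weaker inhibitor, a lower number a stronger inhibitor), compound 3 gives 780 nM.
Compound 1 `CN(C)CCn1cnnc1-c1cc(Oc2ccc(NC(=O)N/N=C/c3c(Cl)cccc3Cl)cc2F)ccn1`: in this assay compound 1 gives 1410 nM.
Compound 2 `CN(C)CCn1cnnc1-c1cc(Oc2ccc(NC(=O)N/N=C/c3ccccc3)cc2F)ccn1`: in this assay compound 2 gives 1860 nM.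

Compound 3 has the lowest of the three numbers. Its gap to compound 1 lies within the scatter, so those two cannot be ordered. Within the data shown here, only one step stands beyond the scatter: a 2.4-fold lower number from compound 2 to compound 3 (0.38 log units; beyond the scatter), a modest one. The other two, a 1.3-fold higher number from compound 1 to compound 2 (0.12 log units; within the scatter) and a 1.8-fold lower number from compound 1 to compound 3 (0.26 log units; within the scatter), are within it.

Compound 4 `CN(C)CCn1cnnc1-c1cc(Oc2ccc(NC(=O)N/N=C/c3ccc(O)c(F)c3)cc2F)ccn1` has not yet been measured. It differs from compound 3 by 3-fluoro-4-hydroxyphenyl in place of 4-chlorophenyl on a carbon with a double bond to nitrogen. The measured steps vary only the chlorine on this ring; none of them involves a hydroxy or fluoro group, so they bear on the new change only in part. Since a 2.4-fold lower number from compound 2 to compound 3 (0.38 log units; beyond the scatter) shows that the chloro group went with a modest lowering, its removal in compound 4 is expected to undo some of that, while the entering groups remain an open question. A small rise, a 1.7-fold higher number from compound 3 to compound 4 (0.22 log units; within the scatter), is therefore expected, with wide uncertainty. Compound 4 is estimated at 1300 nM, ranging from 400 nM to 4000 nM.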

Compound 4, half-maximal inhibitory concentration: 13400 nM
For compound 4 the middle estimate is 10-fold (1.01 log units) below the measured one; measured number outside the range, above it.
By their numbers in this assay, from the lowest: compounds 3, 1 and 2 (each within the scatter of the next, the first and the last beyond it); then compound 4.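

This position tolerates less than the chlorine changes suggested: in this assay, those steps were modest at most, whereas 3-fluoro-4-hydroxyphenyl in place of 4-chlorophenyl gives a 17-fold higher number from compound 3 to compound 4 (1.24 log units; beyond the scatter). The rise holds from the other two rings as well, with a 7.2-fold higher number from compound 2 to compound 4 (0.86 log units; beyond the scatter) and a 9.5-fold higher number from compound 1 to compound 4 (0.98 log units; beyond the scatter), and the entering group has a hydrogen-bond donor and a hydrogen-bond acceptor, where each of the rings it replaces has none. No measurement shown explains the rise.

Which of the hydroxy and fluoro groups goes with the higher number stays open, as the compounds shown carry them only together. As far as these compounds go, how a methoxy group or an amine on this ring would compare also remains unknown.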